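The compounds below may be only part of what the source reports. "The series", "measured", "known", "first", "only" and "open" are said of these compounds alone.

Of the compounds shown here, two that share one core have been tested in an assay on CHO cells for displacement of a labelled ligand from C-X-C chemokine receptor type 1 (Homo sapiens); on this read-out higher numbers stand for weaker inhibition and lower numbers for stronger inhibition. Compound 1 `CN(C)S(=O)(=O)c1c(Cl)ccc(N/C(=N/C#N)Nc2ccccc2Br)c1O` gives 55 nM. Among the measured compounds shown here, compound 2 `Cc1ccc(N/C(=N/C#N)Nc2ccccc2Br)c(O)c1S(=O)(=O)N(C)C` gives 187 nM, which is the higher of the two numbers, with compound 1 as its only neighbour. For the measured compounds named here, the single measured step between them, a 3.4-fold higher number from compound 1 to compound 2 (0.53 log units; beyond the scatter), exchanged a chloro for a methyl on the aromatic carbon. Compound 3 `CN(C)S(=O)(=O)c1c(F)ccc(N/C(=N/C#N)Nc2ccccc2Br)c1O` differs from compound 2 by fluoro in place of methyl on an aromatic carbon, so a halogen comes back to the carbon that carried chloro in compound 1. Going by the values given here, only that one step bears on the change, and it ran toward weaker inhibition when chloro left; with fluoro entering, a step back toward lower numbers in this assay is expected, though probably not a full return. The expected step is a 2.2-fold lower number from compound 2 to compound 3 (0.34 log units; beyond the scatter). Compound 3 is estimated at 85 nM, within a range from 35 nM to 210 nM.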

Compound 3, half-maximal inhibitory concentration: 192 nM
The estimate for compound 3 lay 2.3-fold (0.35 log units) below the measured number; the measured number falls inside the stated range.
By their numbers in this assay, from the lowest: compound 1; then compounds 2 and 3 (each within the scatter of the next).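

In this assay, fluoro in place of methyl on this aromatic carbon gives a 1.0-fold higher number from compound 2 to compound 3 (0.01 log units; within the scatter) and so does not separate the two groups, while fluoro in place of chloro gives a 3.5-fold higher number from compound 1 to compound 3 (0.54 log units; beyond the scatter) and sets chloro apart. Having a halogen on this carbon is therefore not enough for the lower number: among the three compounds only the chloro of compound 1 goes with it, and fluoro, the other halogen, goes against any pattern shared by halogens. No measured evidence explains why chloro differs from the other two groups here.

Going by these compounds, it remains open whether a methoxy group, a trifluoromethyl group or a nitrile on this carbon would give a number near that of compound 1 or near that of compound 2. On these data alone, it is also open whether the step from chloro to fluoro keeps its size when the rest of the shared core changes.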